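Swapping the five-membered ring on the cyclopropane

A few compounds are considered here, and "the series" means these few. Any claim that something is new, unique, unknown or untested is made for them only; others in the source may bear on it.

Compound 1 `CC[C@H](C)[C@H](N)CN(C(=O)[C@@H]1C[C@H]1c1ccccn1)c1ccc(-c2ccccc2)cc1` gives 130 nM in a functional assay for agonist activity at G protein-coupled receptor 88 (Homo sapiens), read by HTRF and cAMP accumulation; on this read-out lower numbers stand for an effect already at smaller amounts and higher numbers for an effect only at larger amounts of compound. Compound 2 `CC[C@H](C)[C@H](N)CN(C(=O)[C@@H]1C[C@H]1c1cccs1)c1ccc(-c2ccccc2)cc1` gives 360 nM, the higher of the two numbers. Within the data shown here, the only measured step, a 2.8-fold higher number from compound 1 to compound 2 (0.44 log units; beyond the scatter), bears on the new change. Compound 3 `CC[C@H](C)[C@H](N)CN(C(=O)[C@@H]1C[C@H]1c1csc(C)n1)c1ccc(-c2ccccc2)cc1` differs from compound 2 by 2-methyl-1,3-thiazol-4-yl in place of thiophen-2-yl on a saturated ring carbon; the entering ring again carries a ring nitrogen, as in compound 1. The number for compound 3 is therefore expected to move modestly downward, a 1.8-fold lower number from compound 2 to compound 3 (0.26 log units; within the scatter). The estimate for compound 3 is 200 nM, with a range from 80 nM to 500 nM.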

Compound 3, half-maximal effective concentration: 1500 nM
For compound 3 the middle estimate is 7.5-fold (0.88 log units) below the measured one; the whole stated range lies below it.
By their numbers in this assay, from the lowest: compound 1; then compound 2; then compound 3.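

Carrying a ring nitrogen does not by itself bring the number down at this saturated ring carbon: in this assay, the change to 2-methyl-1,3-thiazol-4-yl brings a 4.2-fold higher number from compound 2 to compound 3 (0.62 log units; beyond the scatter), and against the pyridin-2-yl ring it brings a 12-fold higher number from compound 1 to compound 3 (1.06 log units; beyond the scatter). The two rings with a ring nitrogen thus stand at opposite ends of the order, with thiophen-2-yl in the middle. Nothing available explains this order.

Going by these compounds, compound 3 changes the ring and adds a methyl at once, so the share of each stays open. A plain 1,3-thiazol-4-yl, without the methyl, would separate the two.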